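Removing the hydroxyl from the piperidine side chain

This account rests on a few compounds, and the source may have more. Where it says the series, first, only, none or still open, it means among the compounds named here.

Compound 3 `Cc1cc(C)c(S(=O)(=O)N2CCC(N3CCC(CCO)CC3)CC2)c(C)c1` gives 19 nM in a functional assay on DLD-1 cells (Homo sapiens) for antiproliferative activity, read by CellTiter-Glo, with a stated time of 72 h (a higher number here means a weaker inhibitor, a lower number a stronger inhibitor), the lowest number of the three measured; compound 2 `Cc1cc(C)c(S(=O)(=O)N2CCC(N3CCC(O)CC3)CC2)c(C)c1` gives 106 nM and compound 1 `Cc1ccc(-c2ccccc2S(=O)(=O)N2CCC(N3CCC(C)CC3)CC2)cc1` gives 366 nM. Compound 4 `Cc1cc(C)c(S(=O)(=O)N2CCC(N3CCC(C)CC3)CC2)c(C)c1` differs from compound 3 by hydrogen in place of hydroxymethyl on a saturated chain carbon bound to a saturated ring carbon. Among the compounds with values here, the one measured step that bears on this is a 5.6-fold lower number from compound 2 to compound 3 (0.75 log units; beyond the scatter), which shows the hydroxyl-bearing chain carrying weight. Compound 1 also bears 4-methylpiperidin-1-yl, though on a different aryl, and its value sits well above compound 3. A step back toward higher numbers is therefore expected, a 7.9-fold higher number from compound 3 to compound 4 (0.90 log units; beyond the scatter), of a size comparable to the measured hydroxyl step. Compound 4 is estimated at 150 nM, with a range of 40 nM to 550 nM.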

Compound 4, half-maximal inhibitory concentration: 0.03 nM
Estimate against measurement, compound 4: 5000-fold (3.70 log units) above, and the stated range ends above it.
By their numbers in this assay, from the lowest: compound 4; then compound 3; then compound 2; then compound 1.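

In this assay, replacing 4-(2-hydroxyethyl)piperidin-1-yl with 4-methylpiperidin-1-yl gives a 630-fold lower number from compound 3 to compound 4 (2.80 log units; beyond the scatter) and so the hydroxyl is not required at this position. Methyl in place of hydroxy on a saturated ring carbon gives a 3500-fold lower number from compound 2 to compound 4 (3.55 log units; beyond the scatter) and this makes the earlier gain from hydroxy to 2-hydroxyethyl look small. Compound 1 carries the same 4-methylpiperidin-1-yl on a different aryl yet gives 366 nM and so this group alone does not set the value.

Nothing shown here explains the size of this change. Going by these compounds, whether an ethyl, a longer alkyl chain or a methoxy at this position would hold the value remains open.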